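From Ethyl to Propyl on the Shared Core

The source may hold more compounds than are shown below. What is called first, only, known or untested is meant among the compounds shown, and "the series" means these compounds.

Compound 3 `CCc1ccccc1-n1nc(C)c2c1NC(=O)[C@H](C)S[C@@H]2c1ccc(Oc2ccccc2)cc1` was characterised in an assay on isolated protein for agonist activity at Bile acid receptor (Homo sapiens), read by AlphaScreen, with a stated time of 30 min (on this read-out higher numbers stand for an effect only at larger amounts of compound and lower numbers for an effect already at smaller amounts), where compound 3 gives 1100 nM. Of the two compounds that returned a number, compound 3 has the lower one, but its nearest neighbour compound 2 `Cc1nn(-c2ccccc2I)c2c1C(c1ccc(Oc3ccccc3)cc1)SC(C)C(=O)N2` sits within the scatter: in this assay compound 2 gives 1300 nM. Compound 1 `COC(=O)c1cccc(-c2ccc([C@H]3S[C@@H](C)C(=O)Nc4c3c(C)nn4-c3ccccc3C)cc2)c1` is recorded in this assay as "not active" (no number reported), so no number is available for compound 1.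

Compound 4 `CCCc1ccccc1-n1nc(C)c2c1NC(=O)[C@H](C)S[C@@H]2c1ccc(Oc2ccccc2)cc1` is the next compound and carries the change methyl in place of hydrogen on a saturated chain carbon, two bonds along the chain from an aromatic carbon relative to compound 3. Within the data shown here, no pair of measured compounds isolates this change, so there is no measured step to lean on. Given that compound 2 and compound 3 differ only within the scatter, and that the change adds a single carbon to a chain, compound 4 is expected to show a step of a 1.1-fold lower number from compound 3 to compound 4 (0.04 log units; within the scatter) that stays within the usual scatter, with no clear direction. Compound 4 is therefore estimated at 1000 nM, within a range from 400 nM to 3000 nM.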

Compound 4, half-maximal effective concentration: 1100 nM
The estimate for compound 4 lay 1.1-fold (0.04 log units) below the measured number, within the range that was stated.
By their numbers in this assay, from the lowest: compounds 3, 4 and 2 (each within the scatter of the next).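

The change from ethyl to propyl on the shared core gives no change at the digits printed from compound 3 to compound 4 (within the scatter) in this assay. Among these compounds, this is the first step that isolates a single change, as none of the earlier compounds formed such a pair, and it shows that adding a methyl at this place on the saturated chain, two bonds along from an aromatic carbon, leaves the read-out unmoved. Nothing measured here offers an explanation for this flat step.

With only this one step at the position, the compounds shown do not tell how far the chain can grow before the number moves. From the compounds shown here alone, whether a longer chain such as butyl, a branched group such as isopropyl, or an amine in place of the propyl group would also leave the number unmoved remains open.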